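Trifluoromethyl for Nitro: Cytotoxicity Before the Measurement

A few compounds are considered here, and "the series" means these few. Any claim that something is new, unique, unknown or untested is made for them only; others in the source may bear on it.

Compound 1, `c1ccc2cc(C3CNCCNCCNCCN3)ccc2c1`: > 200000 nM
Compound 2, `CC(C)(C)C1CNCCNCCNCCN1`: > 200000 nM
Compound 3, `O=[N+]([O-])c1ccc(C2CNCCNCCNCCN2)cc1`: > 200000 nM

Three compounds sharing one core have been examined in an ADME assay on HEK293 cells (Homo sapiens) for cytotoxicity; on this read-out higher numbers stand for an effect only at larger amounts of compound and lower numbers for an effect already at smaller amounts. Each of the three values is a limit of the assay and not a number. Within the data shown here, compound 3 stands at the limit of > 200000 nM in this assay, at which 3 of the 3 values shown sit, and compound 1 and compound 2 sit at the same limit, so nothing orders the three and no step between any two of them has been recorded.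

Compound 4, `FC(F)(F)c1ccc(C2CNCCNCCNCCN2)cc1`, has not yet been measured in this assay. It differs from compound 3 by trifluoromethyl in place of nitro on an aromatic carbon. With no measured step to build on and every shown value resting at the limit, the expectation is for no step beyond the usual scatter, and most likely for another limit rather than a number. The expected step is a number no higher from compound 3 to compound 4 (the limit leaves the size open). Compound 4 is therefore estimated at 200000 nM, with a range from 100000 nM to 400000 nM.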

Compound 4, half-maximal effective concentration: 73000 nM
Estimate against measurement, compound 4: 2.7-fold (0.44 log units) above, outside the stated range (below it).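

In this assay the exchange of nitro for trifluoromethyl on an aromatic carbon para to a large group gives an at least 2.7-fold lower number from compound 3 to compound 4 (0.43 log units; beyond the scatter) and shows that the group at this position can change the read-out. Compound 4 is the only compound shown with a number rather than a limit, which reveals that a compound on the shared core can produce an effect within the range of this assay, something the earlier compounds could not show: the limit of > 200000 nM in this assay, at which 3 of the 4 values shown sit. As far as these compounds go, compound 3 rests on a limit, so the step gives only a smallest size, and its full size remains unknown.

The compounds shown leave open whether an amine, a carboxylic acid or a methoxy group at this position would also give a number. They also leave open why trifluoromethyl differs from nitro here, as nothing shown points to a cause.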